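This account rests on a few compounds, and the source may have more. Where it says the series, first, only, none or still open, it means among the compounds named here.

Three close relatives of one shared core have been examined in an assay on isolated protein for inhibition of Dihydrofolate reductase (Homo sapiens), read by spectrophotometry, using NADPH, with stated times of 5 s and 6 min, tested at 5 uM; on this read-out lower numbers stand for a weaker effect and higher numbers for a stronger effect at the one concentration tested. Compound 1 `NC1=NC2(CCOCC2)N(OCCCOc2cc(Cl)c(Cl)cc2Cl)C(N)=N1` carries a 2,4,5-trichlorophenyl on an oxygen on a saturated carbon. In this assay compound 1 reaches > 90%, which is a limit of the assay rather than a number. Compound 2 `NC1=NC2(CCOCC2)N(OCCCOc2ccccc2Cl)C(N)=N1` carries a 2-chlorophenyl in that place, and in this assay compound 2 gives 83.3%. The change between them amounts to a number at least 6.7 percentage points lower from compound 1 to compound 2 (that floor lies within the scatter). Compound 3 `NC1=NC2(CCSCC2)N(OCCCOc2ccc(Cl)cc2)C(N)=N1` carries a 4-chlorophenyl on an oxygen on a saturated carbon. In this assay compound 3 reaches > 90%, again a limit and not a number, so compound 3 can only be placed at that limit. This fits (the limit of > 90% in this assay, at which 2 of the 3 values shown sit).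

Compound 4 `NC1=NC2(CCSCC2)N(OCCCOc2cccc(Br)c2)C(N)=N1` has not yet been measured. It differs from compound 3 by 3-bromophenyl in place of 4-chlorophenyl on an oxygen on a saturated carbon. Within the data shown here, the only measured step that alters the same aromatic group, from compound 1 to compound 2, sat at a floor within the scatter, so no change beyond the scatter is expected here either. The expected step is a number at least 2 percentage points lower from compound 3 to compound 4 (that floor lies within the scatter). Compound 4 is therefore estimated to give 88% in this assay, between 75% and 95%, with a fair chance that the read-out is again reported only as a limit.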

Compound 4, a percentage reported as inhibition, at one concentration (the size of the read-out at that concentration, not a potency): 84.2%
Estimate against measurement, compound 4: 3.8 percentage points above; measured number inside the range.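

In this assay, the change from 4-chlorophenyl to 3-bromophenyl gives a number at least 5.8 percentage points lower from compound 3 to compound 4 (that floor lies within the scatter), so this position has now been varied on the second version of the shared core without any change beyond the scatter. Unlike compound 3, compound 4 gives an actual number rather than a limit, which offers a firmer reference point for later changes at this position. Even so, the full size of the step stays hidden because the read-out for compound 3 is only a limit: the limit of > 90% in this assay, at which 2 of the 4 values shown sit.

This single step replaces chlorine with bromine and also changes the halogen's place on the ring, so the compounds shown leave open which of the two matters, and a 3-chlorophenyl or a 4-bromophenyl would be needed to separate them. Also open, going by these compounds, is how an unsubstituted phenyl, a phenyl bearing an amine or a carboxylic acid, or a longer chain leading to the ring would behave, and a reading at one concentration says nothing about potency.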